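Phenyl to 2,2-dimethoxyethyl on a chain of the core

A few compounds are considered here, and "the series" means these few. Any claim that something is new, unique, unknown or untested is made for them only; others in the source may bear on it.

Measured compounds:
compound 1 `CCCCn1cnc2c(Nc3ccccc3)nc(NCOCc3ccc(/C=C/C(=O)Nc4ccccc4N)cc3)nc21` — 51.9%
compound 2 `Nc1ccccc1NC(=O)c1ccc(Cn2cnc3c(Nc4ccccc4)nc(Cl)nc32)cc1` — 83.5%
compound 3 `Nc1ccccc1NC(=O)c1ccc(CNc2nc(Cl)nc3c2ncn3Cc2ccccc2)cc1` — 11.5%

Of the compounds shown here, three have been measured in a functional assay on HCT-116 cells (Homo sapiens) for antiproliferative activity, read by CCK-8 assay, with a stated time of 72 h, tested at 8 uM; a lower number here means a weaker effect, a higher number a stronger effect of the compound at the concentration tested. Compound 2 gives 83.5%, compound 1 gives 51.9%, and compound 3 gives 11.5%. Compound 3 thus stands lowest of the three: its number lies beyond the scatter under that of compound 1, its nearest neighbour, and further still under that of compound 2. Among the three there is no pair that differs in one place only, so no measured step is at hand to guide the next compound.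

Compound 4 `COC(CCn1cnc2c(NCc3ccc(C(=O)Nc4ccccc4N)cc3)nc(Cl)nc21)OC` is built from compound 3 by one change: 2,2-dimethoxyethyl in place of phenyl on a saturated chain carbon bound to an aromatic nitrogen. The benzyl group of compound 3 becomes a 3,3-dimethoxypropyl chain, the rest of the molecule staying as it is.

Within the data shown here, with no comparable step among the measured compounds, the direction of this change can only be judged from the three numbers. Compound 3 sits low, and the other two show that the shared core can reach much higher numbers. A moderate upward step is expected for compound 4, as a number 13.5 percentage points higher from compound 3 to compound 4 (beyond the scatter) expresses. Compound 4 is estimated at 25%, within a range from 5% to 60%.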

Compound 4, a percentage reported as inhibition, at one concentration (the size of the read-out at that concentration, not a potency): 11.9%
For compound 4 the middle estimate is 13.1 percentage points above the measured one; the measured number falls inside the stated range.
By their numbers in this assay, from the lowest: compounds 3 and 4 (each within the scatter of the next); then compound 1; then compound 2.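

In this assay, the exchange of phenyl for 2,2-dimethoxyethyl on a saturated chain carbon bound to an aromatic nitrogen gives a number 0.4 percentage points higher from compound 3 to compound 4 (within the scatter), the first step measured at this position. It shows that, at the concentration tested, a six-membered aromatic ring of carbon only and a group with no ring and two hydrogen-bond acceptors cannot be told apart here, even though the two groups have the same count of heavy atoms and differ in both ring and oxygen content. No measurement at hand bears on why the read-out stays within the scatter across this change.

This single step, with compound 3 at 11.5% and compound 4 at 11.9%, leaves open whether the read-out responds to this position at all or whether these two groups merely happen to give similar numbers. Going by these compounds, a terminal amine or a carboxylic acid on the chain, or a longer chain, would test this, and it also remains open whether the same exchange would read alike on a compound with a higher starting number.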